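The source may hold more compounds than are shown below. What is called first, only, known or untested is meant among the compounds shown, and "the series" means these compounds.

Measured in a functional assay on HCT-116 cells (Homo sapiens) for antiproliferative activity, read by MTT assay, with a stated time of 72 h; a higher number here means a weaker inhibitor, a lower number a stronger inhibitor:
- compound 1 `COc1ncc(-c2ccc3c(c2)NC(=O)CO3)cc1NS(=O)(=O)c1ccc(F)cc1`: 24900 nM
- compound 2 `O=C1COc2ccc(-c3cnc(Cl)c(NS(=O)(=O)c4ccc(F)cc4)c3)cc2N1`: > 40000 nM (a limit of the assay)

Going by the values given here, compound 1 at 24900 nM holds the only actual number so far. Compound 2 reads > 40000 nM, which is a limit and not a number.

The next analogue is compound 3 `COc1ncc(-c2ccc3c(c2)N(C2CC2)C(=O)CO3)cc1NS(=O)(=O)c1ccc(F)cc1`, with cyclopropyl in place of hydrogen on an amide-type nitrogen in a ring.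

Among the compounds with values here, the only measured step, an at least 1.6-fold higher number from compound 1 to compound 2 (0.20 log units; that floor lies within the scatter), is chloro in place of methoxy on an aromatic carbon. It does not touch this nitrogen, and its floor lies within the scatter, so it gives no size to carry over. The expectation therefore rests on compound 1 at 24900 nM.

No change beyond the scatter is expected in this assay, and the estimated step is a 1.1-fold lower number from compound 1 to compound 3 (0.03 log units; within the scatter). The estimate for compound 3 is 23000 nM, with an expected range of 8000 nM to 40000 nM.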

Compound 3, half-maximal inhibitory concentration: 24300 nM
Compound 3: the middle estimate sits 1.1-fold (0.02 log units) below what was measured; the measured number falls inside the stated range.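

The amide-type nitrogen in the ring accepts a substituent with no readable change in this assay: a 1.0-fold lower number from compound 1 to compound 3 (0.01 log units; within the scatter), with cyclopropyl in place of hydrogen. Compound 3 therefore shows that replacing the amide hydrogen with this three-membered ring leaves the read-out within the scatter, a point about this nitrogen that the chloro for methoxy step could not give. One value in the series is a limit of the assay and not a number: the limit of > 40000 nM in this assay, at which 1 of the 3 values shown sits.

A single substituent does not show how this nitrogen responds to other groups, such as a longer chain, an amine or a carboxylic acid. The compounds shown also leave open whether any change at this nitrogen can move the value in this assay beyond the scatter.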